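From methoxymethyl amide to ethyl urea on a shared core

A few compounds are considered here, and "the series" means these few. Any claim that something is new, unique, unknown or untested is made for them only; others in the source may bear on it.

Compound 1, `COc1cccc(Oc2ccc(NC(C)=O)cc2)c1`: in an assay on isolated protein for binding affinity to melatonin receptor type 1B (Homo sapiens) (a higher number here means a weaker inhibitor, a lower number a stronger inhibitor), compound 1 gives 4.1 nM.
Compound 2, `C/C=C/C(=O)Nc1ccc(Oc2cccc(OC)c2)cc1`: in this assay compound 2 gives 2.1 nM.
Compound 3, `COCC(=O)Nc1ccc(Oc2cccc(OC)c2)cc1`: in this assay compound 3 gives 5.9 nM.

Compound 3 holds the highest of the three numbers. Its nearest neighbour is compound 1, and the step between them is small: a 1.4-fold higher number from compound 1 to compound 3 (0.16 log units; within the scatter). Its furthest neighbour is compound 2, and that step is the only one among the three that is beyond the scatter: a 2.8-fold higher number from compound 2 to compound 3 (0.45 log units; beyond the scatter).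

Compound 4, `CCNC(=O)Nc1ccc(Oc2cccc(OC)c2)cc1`, differs from compound 3 in one place: ethylamino in place of methoxymethyl on a carbonyl carbon. The measured steps all sit on the same carbonyl carbon and so bear on this change, but each of them exchanges one carbon-linked group for another: a 2.0-fold lower number from compound 1 to compound 2 (0.29 log units; within the scatter), alongside the two steps above. None of them puts a nitrogen-linked group on that carbon, so the direction is not anchored by a measured step. The three changes seen so far have stayed modest, and a step of similar size or none beyond the scatter is therefore expected: a 1.4-fold higher number from compound 3 to compound 4 (0.13 log units; within the scatter). In this assay compound 4 is estimated to give 8 nM, with a range from 2.5 nM to 25 nM.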

Compound 4, inhibition constant: 250 nM
For compound 4 the middle estimate is 31-fold (1.49 log units) below the measured one; the measured number lies above the stated range.
By their numbers in this assay, from the lowest: compounds 2, 1 and 3 (each within the scatter of the next, the first and the last beyond it); then compound 4.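

On this carbonyl carbon, the carbon-linked groups seen earlier gave numbers in the low nanomolar range, but ethylamino sets itself apart: in this assay there is a 42-fold higher number from compound 3 to compound 4 (1.63 log units; beyond the scatter) even though the swap for methoxymethyl leaves the count of 3 heavy atoms unchanged, adds no ring and carries no net charge. The change exchanges the chain's oxygen for nitrogen and so replaces 1 hydrogen-bond acceptor with 1 hydrogen-bond donor, and the same separation appears with the other two groups, with a 120-fold higher number from compound 2 to compound 4 (2.08 log units; beyond the scatter) against prop-1-en-1-yl and a 61-fold higher number from compound 1 to compound 4 (1.79 log units; beyond the scatter) against methyl, so none of the compounds shown goes against it. Nothing available here explains why this nitrogen-linked group stands so far from the other three.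

Going by these compounds, it remains open whether the large step belongs to the nitrogen link itself, to the hydrogen on that nitrogen or to the ethyl chain it carries. An ethoxy group, a dimethylamino group or a methylamino group on the same carbonyl carbon would begin to separate these readings.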